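The compounds below may be only part of what the source reports. "The series", "measured", "known", "first", "only" and "open" are said of these compounds alone.

Measured compounds:
Compound 1, `CCCN(Cc1ccc(OCCn2c(=O)ccn(C)c2=O)c(OC)c1)C(CC(=O)O)c1ccc(Cl)cc1`, in an ADME assay on Caco-2 cells (Homo sapiens) for permeability, read by LC-MS, with a stated time of 2 h (a higher number here means that the compound crosses the layer faster, a lower number that the compound crosses the layer more slowly), compound 1 gives 1 nm/s.
Compound 2, `CCCN(Cc1ccc(OCCn2c(=O)ccn(C)c2=O)c(OC)c1)C(CC(=O)O)c1ccc2c(c1)CCO2`, in this assay compound 2 gives 2 nm/s.
Compound 3, `COc1cc(CN(CC(C)C)C(CC(=O)O)c2ccc3c(c2)CCO3)ccc1OCCN1C(=O)CCC1=O`, in this assay compound 3 gives 0.2 nm/s.

Compound 1 and compound 2 share one core and differ only in the group carried on a saturated chain carbon bound to an amine nitrogen and a saturated chain carbon. The change between them is a group of 7 heavy atoms (6 carbon, 1 chlorine; one six-membered aromatic ring of carbon only) in place of a group of 9 heavy atoms (8 carbon, 1 oxygen; one five-membered non-aromatic ring with 1 hetero atom, one six-membered aromatic ring of carbon only), on a saturated chain carbon bound to an amine nitrogen and a saturated chain carbon, and it made the step of a 2.0-fold lower number from compound 2 to compound 1 (0.30 log units; within the scatter). This step is within the usual scatter of repeated measurements, so the two numbers cannot be told apart with confidence.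

Compound 3 sits on a different core; how its core differs from the core of compound 2 is not broken down here. Among the three measured compounds, compound 3 has the lowest number in this assay, and its gaps to compound 1 and compound 2 lie beyond the scatter.

Compound 4, `COc1cc(CN(CC(C)C)C(CC(=O)O)c2ccc(Cl)cc2)ccc1OCCN1C(=O)CCC1=O`, has not yet been measured. It is obtained from compound 3 by the same change that leads from compound 2 to compound 1: a group of 7 heavy atoms (6 carbon, 1 chlorine; one six-membered aromatic ring of carbon only) in place of a group of 9 heavy atoms (8 carbon, 1 oxygen; one five-membered non-aromatic ring with 1 hetero atom, one six-membered aromatic ring of carbon only), on a saturated chain carbon bound to an amine nitrogen and a saturated chain carbon. Among the compounds shown, this change occurs two times in all.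

For the measured compounds named here, since the one measured instance of this change gave a step within the scatter, compound 4 is expected to land close to compound 3, with an estimated step of a 1.3-fold lower number from compound 3 to compound 4 (0.12 log units; within the scatter) in this assay, because compound 3 gives 0.2 nm/s and the earlier step was a 2.0-fold lower number from compound 2 to compound 1 (0.30 log units; within the scatter). Compound 4 is estimated at 0.15 nm/s, with a likely range from 0.05 nm/s to 0.5 nm/s.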

Compound 4, apparent permeability: 3 nm/s
For compound 4 the middle estimate is 20-fold (1.30 log units) below the measured one; the whole stated range lies below it.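

On the core of compound 3, putting the 4-chlorophenyl group in place of the other group, on the same saturated chain carbon, gave a 15-fold higher number from compound 3 to compound 4 (1.18 log units; beyond the scatter) in this assay, a large step that lies beyond the scatter. Set beside the earlier result, this shows that the same change did not behave alike on the two cores, so the step seen on one core could not be carried over to the other in this series: the same change on two cores in this assay, a 2.0-fold lower number (0.30 log units; within the scatter) from compound 2 to compound 1 and a 15-fold higher number (1.18 log units; beyond the scatter) from compound 3 to compound 4, 30-fold (1.48 log units) apart, beyond the scatter of two such steps It does not show which difference between the cores matters or why the outcome changes, and with only one pair on each core it gives no general rule about how this change behaves on other cores.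

The compounds shown leave open whether a third core, for example one with a butyl chain on the amine nitrogen, would follow the first pair, the second pair or neither. They also leave open how far the large step is specific to the 4-chlorophenyl group, since a 4-fluorophenyl or 4-bromophenyl group in the same place, or a methyl ester in place of the carboxylic acid, could each be compared on both cores.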